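A few compounds are considered here, and "the series" means these few. Any claim that something is new, unique, unknown or untested is made for them only; others in the source may bear on it.

Working notes on the thiourea series.

Compound 3 `CCCCS(=O)(=O)Nc1ccc(C/N=C(\S)NCc2ccc(C(C)(C)C)cc2)cc1` is the reference point here. Among the measured compounds shown here, in a functional assay for antagonist activity at Vanilloid receptor (Rattus norvegicus) (on this read-out lower numbers stand for stronger inhibition and higher numbers for weaker inhibition), compound 3 gives 4100 nM, the lowest of the three numbers so far. Compound 1 `CC(C)(C)c1ccc(C/N=C(\S)NCc2ccc(C(F)(F)F)cc2)cc1` gives 12400 nM in this assay, and compound 2 `CC(C)(C)c1ccc(C/N=C(\S)NCc2ccc(OS(C)(=O)=O)cc2)cc1` gives 9300 nM. For the measured compounds named here, the only one-place step among the measured compounds is a 1.3-fold lower number from compound 1 to compound 2 (0.12 log units; within the scatter), and that change sits on the aromatic ring, not on the sulfonyl group.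

Compound 4 `CN(C)S(=O)(=O)Nc1ccc(C/N=C(\S)NCc2ccc(C(C)(C)C)cc2)cc1` has not yet been measured. It differs from compound 3 by dimethylamino in place of butyl on a sulfonyl sulfur. Going by the values given here, no measured step touches the substituent on the sulfonyl sulfur, so nothing among the compounds above speaks directly to this change; the one step available, from compound 1 to compound 2, was within the scatter and concerns another place. The expectation is therefore a step of about a 1.2-fold higher number from compound 3 to compound 4 (0.09 log units; within the scatter) in this assay, which means no movement beyond the scatter. Compound 4 is estimated at 5000 nM, with a range from 1500 nM to 16000 nM.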

Compound 4, half-maximal inhibitory concentration: 14600 nM
For compound 4 the middle estimate is 2.9-fold (0.47 log units) below the measured one; low and high end bracket the measured number.
By their numbers in this assay, from the lowest: compound 3; then compounds 2, 1 and 4 (each within the scatter of the next).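

In this assay, among the compounds shown here, the substituent on the sulfonyl sulfur turns out to matter: dimethylamino in place of butyl gives a 3.6-fold higher number from compound 3 to compound 4 (0.55 log units; beyond the scatter) and is the first one-place step to lie beyond the scatter. The only earlier step sat on the aromatic ring and stayed within the scatter, so this position is the first place shown where a single change moves the number measurably, with butyl holding the lower number of the pair. Nothing among the data given accounts for this difference.

The compounds shown leave open whether the step goes with the entering nitrogen or with the loss of the butyl chain, and isopropyl or hexyl on the sulfonyl sulfur would bear on that. Also open, from the compounds shown here alone, is how a cyclic amine such as morpholine would read at this place.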